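Two Limits and a Pyridine Swap on the Amide Carbon

This account rests on a few compounds, and the source may have more. Where it says the series, first, only, none or still open, it means among the compounds named here.

Compound 2 `O=C(Nc1nnc(-c2ccc3c(c2)OCCO3)s1)c1ccc(Cl)nc1` stands at the ceiling of a functional assay on BGC-823 cells (Homo sapiens) for antiproliferative activity, read by MTT assay, with a stated time of 48 h; on this read-out higher numbers stand for an effect only at larger amounts of compound and lower numbers for an effect already at smaller amounts: its result, > 100 ug/mL, is a limit of the assay and not a number. Within the data shown here, its only measured neighbour, compound 1 `Nc1ccc(C(=O)Nc2nnc(-c3ccc4c(c3)OCCO4)s2)cc1`, carries a 4-aminophenyl on the carbonyl carbon where compound 2 carries a 6-chloropyridin-3-yl. In this assay compound 1 also gives only a limit, > 100 ug/mL. Among the measured compounds shown here, the single measured step, a step that the two limits leave unreadable from compound 1 to compound 2, is thus unreadable, and the limit of > 100 ug/mL in this assay, at which 2 of the 2 values shown sit, is all the two results show.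

Compound 3 `O=C(Nc1nnc(-c2ccc3c(c2)OCCO3)s1)c1ccncc1` differs from compound 2 by pyridin-4-yl in place of 6-chloropyridin-3-yl on a carbonyl carbon. For the measured compounds named here, no measured step bears directly on this exchange, and the one step available, a step that the two limits leave unreadable from compound 1 to compound 2, is hidden by the two limits. Since both measured compounds of this core remain at the limit, compound 3 is expected to remain there as well, with no step beyond the scatter in this assay. For compound 3 the expected step is a step that the limit leaves unreadable from compound 2 to compound 3. Compound 3 is estimated at 150 ug/mL in this assay, with a range from 50 ug/mL to 500 ug/mL, most likely reported once more only as a limit.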

Compound 3, half-maximal effective concentration: 41 ug/mL
Estimate against measurement, compound 3: 3.7-fold (0.56 log units) above; the measured number lies below the stated range.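

This position on the carbonyl carbon can move the read-out in this assay: with pyridin-4-yl in place of 6-chloropyridin-3-yl the result is an at least 2.4-fold lower number from compound 2 to compound 3 (0.38 log units; beyond the scatter), and with pyridin-4-yl in place of 4-aminophenyl it is an at least 2.4-fold lower number from compound 1 to compound 3 (0.38 log units; beyond the scatter). Against compound 2, the exchange keeps one six-membered aromatic ring with 1 hetero atom and the same counts of hydrogen-bond donors and acceptors, while the chlorine leaves and the ring is attached as its pyridin-4-yl name states. Neither step has a known upper size, because each starts from a limit and not from a number: the limit of > 100 ug/mL in this assay, at which 2 of the 3 values shown sit.

The step from compound 1 to compound 2 still cannot be read, and the compounds shown do not separate the loss of the chlorine from the change from a pyridin-3-yl to a pyridin-4-yl attachment, which an unsubstituted pyridin-3-yl on the same carbonyl carbon would address. Also open, from the compounds shown here alone, is how a substituent on the pyridin-4-yl ring, such as an amine or a methoxy group, would read in this assay.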